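This account rests on a few compounds, and the source may have more. Where it says the series, first, only, none or still open, it means among the compounds named here.

Two compounds of this series already carry numbers. Compound 1 `O/N=C1/C(c2c[nH]c3ccc(OCc4ccccc4)cc23)=Nc2ccc(OCc3ccccc3)cc21` gives, in a functional assay on MGC-803 cells (Homo sapiens) for cytotoxicity, read by MTT assay, with a stated time of 2 days (on this read-out lower numbers stand for stronger inhibition and higher numbers for weaker inhibition), a value of 14500 nM. Compound 2 `c1ccc(CO/N=C2/C(c3c[nH]c4ccccc34)=Nc3ccccc32)cc1` shares the same core but lacks the two ether side chains of compound 1 and instead bears a phenyl on the oxygen. In this assay compound 2 gives a value of 15400 nM. The two numbers lie within the usual scatter of each other, so nothing separates compound 1 from compound 2 on this read-out.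

The next compound, compound 3 `FC(F)(F)c1ccc(CO/N=C2/C(c3c[nH]c4ccccc34)=Nc3ccccc32)cc1`, differs from compound 2 in one place: trifluoromethyl in place of hydrogen on an aromatic carbon. Going by the values given here, no measured pair in this set shows what such a change does, so the expectation rests on compound 2 alone. Compound 3 is expected to come out close to compound 2, with at most a small gain in potency that need not exceed the scatter, giving a step of a 1.7-fold lower number from compound 2 to compound 3 (0.23 log units; within the scatter). The estimate for compound 3 in this assay is therefore 9000 nM, with a plausible range from 3500 nM to 25000 nM.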

Compound 3, half-maximal inhibitory concentration: 30600 nM
The estimate for compound 3 lay 3.4-fold (0.53 log units) below the measured number, outside the stated range (above it).
By their numbers in this assay, from the lowest: compounds 1, 2 and 3 (each within the scatter of the next, the first and the last beyond it).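

Replacing hydrogen with trifluoromethyl on this aromatic carbon, para to a large group, gives a 2.0-fold higher number from compound 2 to compound 3 (0.30 log units; within the scatter) in this assay. Compound 2 and compound 3 therefore cannot be told apart on this read-out, so this single change, which adds four heavy atoms at this position, brings no clear shift in either direction. Nothing measured here offers an explanation for this result.

From the compounds shown here alone, this is only one substituent at one position, so it remains open whether a methoxy group, an amine or a carboxylic acid on the same carbon would separate from compound 2. Going by these compounds, it also remains open whether trifluoromethyl on another carbon of this ring would behave as it does here.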